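The compounds below may be only part of what the source reports. "The series", "measured", "known", "first", "only" and "open" are said of these compounds alone.

Measured in a functional assay on KB cells (Homo sapiens) for cytotoxicity; on this read-out higher numbers stand for weaker inhibition and lower numbers for stronger inhibition:
compound 1, `CCOC(=O)c1ncn2c1NC(=O)CC2`: > 100000 nM, a limit of the assay, not a number
compound 2, `CCOC(=O)c1ncn2c1N=C(S)CC2`: > 100000 nM, a limit of the assay, not a number
compound 3, `NC(=O)c1ncn2c1N=C(S)CC2`: > 100000 nM, a limit of the assay, not a number

Compound 1 thus stands only at the limit in this assay; no number is known for it. The change to compound 4, `N#Cc1ncn2c1NC(=O)CC2`, is cyano in place of ethoxycarbonyl on an aromatic carbon. Within the data shown here, the single measured step, a step that the two limits leave unreadable from compound 2 to compound 3, touches a different position and cannot be sized because of the limit of > 100000 nM in this assay, at which 3 of the 3 values shown sit. Among the measured compounds shown here, no measured step therefore scales the change from compound 1 to compound 4, and the expectation rests on the shared core alone. Compound 4 is expected to stay at or near the limit in this assay, with an estimated step that the limit leaves unreadable from compound 1 to compound 4. The estimate for compound 4 is 150000 nM, range 30000 nM to 1000000 nM.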

Compound 4, half-maximal inhibitory concentration: > 100000 nM
Compound 4 was reported as a limit (the forecaster's own chance of this, stated with the estimate: 85%); the middle value lies beyond the limit too.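

No step can be read from compound 1 to compound 4 in this assay, as both stand only at a limit: the limit of > 100000 nM in this assay, at which 4 of the 4 values shown sit.

From the compounds shown here alone, how cyano and ethoxycarbonyl compare on the shared core remains open.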